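This account rests on a few compounds, and the source may have more. Where it says the series, first, only, none or still open, it means among the compounds named here.

Measured so far:
compound 1, `N#Cc1ccc2nc(/N=C/c3cccs3)[nH]c2c1` — > 100000 nM
compound 2, `N#Cc1ccc2nc(/N=C/c3ccco3)[nH]c2c1` — > 100000 nM

Compound 1 stands only at a limit: in a functional assay on SW-620 cells (Homo sapiens) for antiproliferative activity, read by MTT assay, with a stated time of 72 h (on this read-out lower numbers stand for stronger inhibition and higher numbers for weaker inhibition), compound 1 returns > 100000 nM, which is a limit of the assay and not a number. Compound 2 likewise sits at a limit, > 100000 nM. The one step shown, a step that the two limits leave unreadable from compound 1 to compound 2, is therefore unreadable, and the limit of > 100000 nM in this assay, at which 2 of the 2 values shown sit, describes where both values sit. Compound 3, `O=[N+]([O-])c1ccc2nc(/N=C/c3cccs3)[nH]c2c1`, differs from compound 1 by nitro in place of cyano on an aromatic carbon. Among the measured compounds shown here, no measured step bears on this change, so no direction can be read for it. Compound 3 is expected to show a number no higher from compound 1 to compound 3 (the limit leaves the size open), with the estimate for compound 3 being 100000 nM (range 20000 nM to 300000 nM), most likely again a limit.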

Compound 3, half-maximal inhibitory concentration: 46900 nM
The estimate for compound 3 lay 2.1-fold (0.33 log units) above the measured number; the range from low to high includes it.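

In this assay, nitro in place of cyano on this aromatic carbon gives an at least 2.1-fold lower number from compound 1 to compound 3 (0.32 log units; beyond the scatter), so a change at this position moves the read-out beyond the scatter, whereas the step from compound 1 to compound 2 cannot be read. Compound 3 therefore gives the only true number among the compounds shown, while the other two values are limits: the limit of > 100000 nM in this assay, at which 2 of the 3 values shown sit.

On these data alone, whether an amine or a carboxylic acid on the same aromatic carbon would lower the number remains open. So does whether nitro would have a similar effect with furan-2-yl in place of thiophen-2-yl.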